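The source may report more compounds than this note shows. Statements on the series, on what has been measured and on what is new or still open speak of the compounds shown alone.

Compound 1 `C=C=CCN(C)Cc1ccccc1` gives 170 nM in an assay on isolated protein for inhibition of Monoamine oxidase (Rattus norvegicus); a higher number here means a weaker inhibitor, a lower number a stronger inhibitor.
Compound 2 `C=C=C(Cc1ccccc1)CN(C)C` gives > 100000 nM in this assay, which is a limit of the assay and not a number.
Compound 3 `C=C=C(CN)Cc1ccc(C)cc1` gives 360 nM in this assay.

Of the three, compound 2 alone stands at the limit of > 100000 nM in this assay, at which 1 of the 3 values shown sits, so its strength can only be bounded, not placed on the scale. Compound 1 and compound 3 both sit at measured values far from that limit. The step followed here leads from compound 2 to compound 4 `C=C=C(CNC)Cc1ccccc1`; the change is hydrogen in place of methyl on an amine nitrogen. Among the measured compounds shown here, no pair of measured compounds differs in exactly one place, so no measured step shows how large an effect this change brings. What can be said is that the two compounds giving real numbers, compound 1 and compound 3, carry an amine nitrogen without the dimethylamino group, whereas compound 2, which carries it, reaches only the limit. On that basis a move toward stronger inhibition in this assay is expected from removing one methyl, though its size is uncertain. Compound 4 is therefore expected to give 2000 nM in this assay, within 300 nM to 30000 nM, an expected step of an at least 50-fold lower number from compound 2 to compound 4 (1.69 log units; beyond the scatter).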

Compound 4, half-maximal inhibitory concentration: 440 nM
The estimate for compound 4 lay 4.5-fold (0.66 log units) above the measured number, and the stated range covers the measured number.
By their numbers in this assay, from the lowest: compound 1; then compounds 3 and 4 (each within the scatter of the next). At a limit, above all of these: compound 2.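

Among the compounds shown here, until now, no measured step showed what this change does; in this assay, going from dimethylamino to methylamino on this amine nitrogen gives an at least 220-fold lower number from compound 2 to compound 4 (2.35 log units; beyond the scatter). Taking away one methyl, a single carbon, is thus enough on this core to bring the compound from the limit onto the measured scale. Compound 2 stands at a limit and not at a number, so the step has a lower bound but no exact size: the limit of > 100000 nM in this assay, at which 1 of the 4 values shown sits.

The compounds shown leave open what happens on this core when the remaining methyl gives way to hydrogen, leaving a primary amine, or to a longer chain such as ethyl. They also leave open whether the same change has a similar effect on a different core.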